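A few compounds are considered here, and "the series" means these few. Any claim that something is new, unique, unknown or untested is made for them only; others in the source may bear on it.

Working notes on the series. Three compounds are measured: compound 1 `COC(=O)/C=C/c1cccc(N(Cc2ccc(/C=C/c3ccc(F)cc3)cc2)C(=O)NC(C)C)c1`, compound 2 `CCOc1cccc(-c2ccc(CN(C(=O)C(C)C)c3cccc(/C=C/C(=O)OC)c3)cc2)c1` and compound 3 `COC(=O)/C=C/c1cccc(N(Cc2ccc(-c3ccc(SC)cc3)cc2)C(=O)C2CCCCC2)c1`, all on a shared core. In an assay on isolated protein with Bile acid receptor (Homo sapiens) as the target (a higher number here means that more compound is needed for the effect, a lower number that less compound is needed), compound 1 gives 348 nM, compound 2 gives 173 nM and compound 3 gives 69 nM. Compound 2 therefore holds the second highest of the three numbers; compound 1 lies within the scatter of it, while compound 3 lies beyond the scatter on the lower side. Compound 4 `COC(=O)/C=C/c1cccc(N(Cc2ccc(-c3ccc(F)c(Cl)c3)cc2)C(=O)C(C)C)c1` is not yet measured. It differs from compound 2 by 3-chloro-4-fluorophenyl in place of 3-ethoxyphenyl on an aromatic carbon, on an aromatic carbon para to a large group. Going by the values given here, no measured pair isolates this change, so in this assay no step beyond the scatter is expected in either direction. The expected step is a 1.2-fold lower number from compound 2 to compound 4 (0.06 log units; within the scatter). Compound 4 is estimated at 150 nM, with a range from 50 nM to 450 nM.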

Compound 4, half-maximal effective concentration: 129 nM
Compound 4: the middle estimate sits 1.2-fold (0.07 log units) above what was measured; low and high end bracket the measured number.
By their numbers in this assay, from the lowest: compounds 3, 4, 2 and 1 (each within the scatter of the next, the first and the last beyond it).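

In this assay, going by these compounds alone, the exchange of 3-ethoxyphenyl for 3-chloro-4-fluorophenyl on this aromatic carbon gives a 1.3-fold lower number from compound 2 to compound 4 (0.13 log units; within the scatter) and is the first step read at this position. The position therefore accepts both aryl groups without a step beyond the scatter, although the hydrogen-bond acceptor counted in 3-ethoxyphenyl is absent from 3-chloro-4-fluorophenyl. No measurement bearing on the result is available to explain it. The compounds shown leave open how an amine or a carboxylic acid on this terminal ring would read.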